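The source may hold more compounds than are shown below. What is called first, only, known or untested is meant among the compounds shown, and "the series" means these compounds.

Measured so far:
compound 1 `CCN(CC)CCCOc1c(OCc2ccccc2)cc(O)c2c(=O)cc(-c3ccccc3)oc12` — 4900 nM
compound 2 `O=c1cc(-c2ccccc2)oc2c(OCCCCN3CCCC3)c(OCc3ccccc3)cc(O)c12` — 3210 nM

In a functional assay on B16 cells (Mus musculus) for cytotoxicity, read by MTT assay, with a stated time of 72 h (a lower number here means a stronger inhibitor, a higher number a weaker inhibitor), compound 2 gives the lowest of the two numbers, and its step to compound 1, a 1.5-fold lower number from compound 1 to compound 2 (0.18 log units; within the scatter), lies within the scatter. Compound 3 `CN1CCN(CCCCOc2c(OCc3ccccc3)cc(O)c3c(=O)cc(-c4ccccc4)oc23)CC1` differs from compound 2 by 4-methylpiperazin-1-yl in place of pyrrolidin-1-yl on a saturated chain carbon, four bonds along the chain from an oxygen on an aromatic ring. Going by the values given here, the only measured step that bears on this amine exchange is a 1.5-fold lower number from compound 1 to compound 2 (0.18 log units; within the scatter), which did not move the number beyond the scatter. The author therefore expects a step of a 1.1-fold higher number from compound 2 to compound 3 (0.04 log units; within the scatter) in this assay for compound 3, with no change beyond the scatter. Compound 3 is estimated at 3500 nM, in the range 1500 nM to 8000 nM.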

Compound 3, half-maximal inhibitory concentration: 2370 nM
Compound 3: middle estimate off by 1.5-fold (0.17 log units), on the high side; the range from low to high includes it.
By their numbers in this assay, from the lowest: compounds 3, 2 and 1 (each within the scatter of the next, the first and the last beyond it).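

At this position, on a saturated chain carbon, four bonds along the chain from an oxygen on an aromatic ring, the step of a 1.4-fold lower number from compound 2 to compound 3 (0.13 log units; within the scatter) in this assay shows that the amine ring can take 4-methylpiperazin-1-yl without a change beyond the scatter. The step of a 2.1-fold lower number from compound 1 to compound 3 (0.32 log units; beyond the scatter) is the first among these compounds to pass the scatter, though only modestly. Nothing given here accounts for either step. Still open, from the compounds shown here alone, is how a morpholine or a piperidine would read at this place, and whether a longer chain carrying 4-methylpiperazin-1-yl would move the number.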